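The source may hold more compounds than are shown below. What is called first, only, known or untested is meant among the compounds shown, and "the series" means these compounds.

Compound 1 `COc1ccc(/C=C/c2ccc3ccccc3c2)cc1[N+](=O)[O-]`: > 5000 nM, a limit
Compound 2 `COc1cc(/C=C/c2ccc3ccccc3c2)cc([N+](=O)[O-])c1OC`: > 10000 nM, a limit
Compound 3 `COc1cc(/C=C/c2ccc3ccccc3c2)cc(N)c1OC`: 6000 nM

These values come from a functional assay on HT-29 cells (Homo sapiens) for inhibition; on this read-out higher numbers stand for weaker inhibition and lower numbers for stronger inhibition. There, compound 2 gives no number, only the limit > 10000 nM. Compound 1 also gives only a limit, > 5000 nM. Of the three, only compound 3 gives a number, 6000 nM.

Compound 4 `COc1c([N+](=O)[O-])cc(/C=C/c2ccc3ccccc3c2)cc1[N+](=O)[O-]` has not yet been measured. It departs from compound 2 by nitro in place of methoxy on an aromatic carbon, ortho to a methoxy group and meta to a nitro group: nitro in place of methoxy on an aromatic carbon.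

Within the data shown here, no measured step makes this exchange, and two bear on it only loosely. Methoxy in place of hydrogen gives a step that the two limits leave unreadable from compound 1 to compound 2. Amino in place of nitro gives an at least 1.6-fold lower number from compound 2 to compound 3 (0.22 log units; that floor lies within the scatter). The first of these has no readable size, and the floor of the second stays within the scatter, so neither supports a clear shift. No step beyond the scatter is therefore expected in this assay, in either direction. The estimated step is a number no higher from compound 2 to compound 4 (the limit leaves the size open). A report of a limit alone is the likeliest outcome. Compound 4 is expected at 10000 nM, with an estimated range of 4000 nM to 30000 nM.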

Compound 4, half-maximal inhibitory concentration: > 5000 nM
Compound 4 was reported as a limit; the forecaster's own chance of this, stated with the estimate: 75%; the middle value does not contradict the limit.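

In this assay compound 4 gives only a limit, > 5000 nM. Compound 1 and compound 2 also stand as limits, so the steps joining compound 4 to compound 2 and to compound 1 cannot be read. The compounds shown leave open whether nitro in place of methoxy or hydrogen on an aromatic carbon changes inhibition at all.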